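A few compounds are considered here, and "the series" means these few. Any claim that something is new, unique, unknown or untested is made for them only; others in the source may bear on it.

Compound 1 `Cc1[nH]c(=O)n(C)c1-c1ccccc1` stands at the edge of what a functional assay on brain (Rattus norvegicus, strain Wistar) for inhibition (on this read-out lower numbers stand for stronger inhibition and higher numbers for weaker inhibition), can report: in this assay compound 1 gives > 100000 nM, which is a limit rather than a number. Compound 2 `CCCCn1c(-c2ccccc2)c(C)[nH]c1=O` likewise gives only the limit > 100000 nM in this assay. Hence a step that the two limits leave unreadable from compound 1 to compound 2. Compound 3 `Cc1[nH]c(=O)n(C)c1-c1ccc(C(C)(C)C)cc1` gives 8400 nM in this assay. Hence an at least 11-fold lower number from compound 1 to compound 3 (1.07 log units; beyond the scatter); the exact size of that step stays open because of the limit of > 100000 nM in this assay, at which 2 of the 3 values shown sit.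

Compound 4 `Cc1[nH]c(=O)n(C)c1-c1ccc(OCCC(C)C)cc1` differs from compound 1 by isopentyloxy in place of hydrogen on an aromatic carbon. Going by the values given here, the one measured step that bears on this change, a group entering on an aromatic carbon in compound 3, was an at least 11-fold lower number from compound 1 to compound 3 (1.07 log units; beyond the scatter). A step of similar kind is therefore expected for compound 4, namely an at least 16-fold lower number from compound 1 to compound 4 (1.22 log units; beyond the scatter), and compound 4 is estimated at 6000 nM in this assay, within 1200 nM to 30000 nM.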

Compound 4, half-maximal inhibitory concentration: 6600 nM
Compound 4: the middle estimate sits 1.1-fold (0.04 log units) below what was measured; low and high end bracket the measured number.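

In this assay, isopentyloxy on this aromatic carbon gives an at least 15-fold lower number from compound 1 to compound 4 (1.18 log units; beyond the scatter), so the drop is not tied to tert-butyl alone and also appears with a chain entering through oxygen. Replacing tert-butyl with isopentyloxy gives a 1.3-fold lower number from compound 3 to compound 4 (0.10 log units; within the scatter), so the two groups cannot be told apart on this read-out. As far as these compounds go, whether an amine, a carboxylic acid or a longer alkoxy chain on this carbon would also lower the number stays open. The exact size of the step from compound 1 also stays open because of a limit: the limit of > 100000 nM in this assay, at which 2 of the 4 values shown sit.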